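Ester in place of the hydrazide on the pyridine core

The source may hold more compounds than are shown below. What is called first, only, known or untested is meant among the compounds shown, and "the series" means these compounds.

Measured compounds:
Compound 1 `CNC(=O)/C=C/c1ccncc1-c1ccc2cccnc2c1`: 1760 nM
Compound 2 `NNC(=O)CCc1ccncc1-c1ccc2ccccc2c1`: 7.7 nM

In an assay on a protein complex for inhibition of CDK8/Cyclin C (Homo sapiens), with a stated time of 1 h (a lower number here means a stronger inhibitor, a higher number a weaker inhibitor), compound 2 gives 7.7 nM, the lowest of the two numbers shown, while compound 1 gives 1760 nM, far beyond the scatter. Compound 3 `CCOC(=O)/C=C/c1ccncc1-c1ccc2ccccc2c1` differs from compound 2 in one place: 2-(ethoxycarbonyl)ethenyl in place of 2-(aminocarbamoyl)ethyl on an aromatic carbon. Among the compounds with values here, no step between measured compounds describes this change, so the expectation rests on compound 2 alone. Because compound 2 stands at 7.7 nM, the change is expected to weaken inhibition, with a step of a 26-fold higher number from compound 2 to compound 3 (1.41 log units; beyond the scatter) beyond the scatter. Compound 3 is therefore estimated at 200 nM, in a range from 20 nM to 2000 nM.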

Compound 3, half-maximal inhibitory concentration: 53.3 nM
Beside the measured number, compound 3's estimate is 3.8-fold (0.57 log units) above it; the range from low to high includes it.
By their numbers in this assay, from the lowest: compound 2; then compound 3; then compound 1.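

In this assay the aromatic carbon opposite the ring nitrogen accepts a different chain: 2-(ethoxycarbonyl)ethenyl in place of 2-(aminocarbamoyl)ethyl gives a 6.9-fold higher number from compound 2 to compound 3 (0.84 log units; beyond the scatter), a modest step. The entering group has no hydrogen-bond donors, so compound 3 shows that donors on this chain are not required for a number of 53.3 nM on this core. No measurement shown here accounts for the step.

The step leaves the double bond and the ester unseparated. On these data alone, how a carboxylic acid or an amine at the end of this chain would compare remains open.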